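The source may report more compounds than this note shows. Statements on the series, on what has been measured and on what is new or still open speak of the compounds shown alone.

In an assay on isolated protein for inhibition of RAC-alpha serine/threonine-protein kinase (Homo sapiens), read by fluorescence, with a stated time of 30 min, tested at 10 uM (a higher number here means more inhibition at the concentration tested (going by the name of the read-out), a lower number less inhibition), three compounds built on a shared core have been measured. Compound 1 `COc1cccc(C(=O)Nc2cc(Sc3ncn[nH]3)c(O)c3ccccc23)c1` gives 19.4%, compound 2 `O=C(Nc1cc(Sc2ncn[nH]2)c(O)c2ccccc12)c1cccc(Cl)c1` gives 46%, and compound 3 `Cc1cccc(C(=O)Nc2cc(Sc3ncn[nH]3)c(O)c3ccccc23)c1` gives 20.2%. Compound 3 stands second highest of the three: its number sits within the scatter of compound 1, while a number 25.8 percentage points lower from compound 2 to compound 3 (beyond the scatter).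

Compound 4 `COc1ccc(C(=O)Nc2cc(Sc3ncn[nH]3)c(O)c3ccccc23)cc1` differs from compound 3 in one place: 4-methoxyphenyl in place of 3-methylphenyl on a carbonyl carbon. The step bearing most closely on this is a number 0.8 percentage points higher from compound 1 to compound 3 (within the scatter), where methyl and methoxy on the same aromatic carbon gave numbers within the scatter of each other. The other step, a number 26.6 percentage points higher from compound 1 to compound 2 (beyond the scatter), concerns chloro, which plays no part here. A step within the scatter is therefore expected, a number 0.2 percentage points lower from compound 3 to compound 4 (within the scatter). Compound 4 is estimated at 20%, with a range from 8% to 36%.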

Compound 4, a percentage reported as inhibition, at one concentration (the size of the read-out at that concentration, not a potency): 30.8%
Compound 4: middle estimate off by 10.8 percentage points, on the low side, and the stated range covers the measured number.
By their numbers in this assay, from the lowest: compounds 1 and 3 (each within the scatter of the next); then compound 4; then compound 2.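

In this assay there is a number 11.4 percentage points higher from compound 1 to compound 4 (beyond the scatter) when 4-methoxyphenyl replaces 3-methoxyphenyl on the carbonyl carbon, so where the methoxy group sits on the ring matters, not only that it is present. Against 3-methylphenyl there is a number 10.6 percentage points higher from compound 3 to compound 4 (beyond the scatter) and against 3-chlorophenyl there is a number 15.2 percentage points lower from compound 2 to compound 4 (beyond the scatter) so 4-methoxyphenyl lands between those groups. Nothing available explains why these numbers differ.

Open, as far as these compounds go, is whether 4-chlorophenyl would gain in the same way, and how a ring carrying an amine or a carboxylic acid would read.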